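This account rests on a few compounds, and the source may have more. Where it says the series, first, only, none or still open, it means among the compounds named here.

Of the compounds shown here, three built on the same core have so far been tested in an assay on isolated protein for inhibition of DNA topoisomerase 1 (Homo sapiens), with a stated time of 30 min, tested at 100 uM; on this read-out higher numbers stand for more inhibition at the one concentration tested (going by the name of the read-out) and lower numbers for less inhibition. In this assay compound 1 `Oc1ccc(-c2cc(-c3ccccc3O)cc(-c3cccc(O)c3)n2)cc1` gives 0%. Compound 2 `Oc1ccccc1-c1cc(-c2ccccc2O)nc(-c2ccccc2O)c1` gives 0% in this assay. Compound 3 `Oc1cccc(-c2cc(-c3ccccc3O)cc(-c3cccc(O)c3)n2)c1` gives 0% in this assay, and so compound 3 stands level with compounds 1 and 2, all three within the scatter of one another. For the measured compounds named here, the one measured step between neighbours, no change at the digits printed from compound 1 to compound 3 (within the scatter), shows that swapping one hydroxyphenyl group for another left the read-out where it was.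

Compound 4 `Oc1cccc(-c2cc(-c3ccccc3O)cc(-c3ccccc3O)n2)c1` is the next member of the series and differs from compound 3 in a single place: 2-hydroxyphenyl in place of 3-hydroxyphenyl on an aromatic carbon. This is again a swap between hydroxyphenyl groups of the same size, of the kind that produced no change at the digits printed from compound 1 to compound 3 (within the scatter), and compound 2, which already carries only 2-hydroxyphenyl groups, gave 0%. The step from compound 3 to compound 4 in this assay is therefore expected to be no change at the digits printed from compound 3 to compound 4 (within the scatter), nothing beyond the scatter. Compound 4 is estimated to give 0% in this assay, with a likely range from -5% to 10%.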

Compound 4, a percentage reported as inhibition, at one concentration (the size of the read-out at that concentration, not a potency): 0%
Beside the measured number, compound 4's estimate shows no gap at the digits printed; the range from low to high includes it.
By their numbers in this assay, from the lowest: compounds 1, 2, 3 and 4 (each within the scatter of the next).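

Swapping 3-hydroxyphenyl for 2-hydroxyphenyl on this aromatic carbon, next to the ring nitrogen, gives no change at the digits printed from compound 3 to compound 4 (within the scatter) in this assay, so 2-hydroxyphenyl, 3-hydroxyphenyl and 4-hydroxyphenyl have now all been seen at this one place with the same printed read-out. The other two steps agree: 3-hydroxyphenyl in place of 2-hydroxyphenyl gives no change at the digits printed from compound 2 to compound 4 (within the scatter), and 2-hydroxyphenyl in place of 4-hydroxyphenyl gives no change at the digits printed from compound 1 to compound 4 (within the scatter). No available data offer an explanation for this flat result.

From the compounds shown here alone, all four compounds carry only hydroxyphenyl groups, so it remains open whether an aminophenyl group, a carboxylic acid or a longer chain at this place would shift the read-out in this assay. Going by these compounds, it also remains open whether any change to the shared core can lift inhibition above the level of these four compounds.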